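This account rests on a few compounds, and the source may have more. Where it says the series, first, only, none or still open, it means among the compounds named here.

Measured so far:
compound 1, `O=C(C1CC1)N1CCN(Cc2nc3ccccc3n2Cc2ccccc2C(F)(F)F)CC1`, gives 56.3% in an assay on isolated protein for inhibition of aldehyde dehydrogenase 1A1 (Homo sapiens), read by spectrophotometry, tested at 10 uM; a higher number here means more inhibition at the concentration tested (going by the name of the read-out), a lower number less inhibition.
compound 2, `CC(C)Cn1c(CN2CCN(C(=O)C3CC3)CC2)nc2ccccc21`, gives 13.1% in this assay.
compound 3, `Cc1ccc(Cn2c(CN3CCN(C(=O)C4CC4)CC3)nc3ccccc32)cc1`, gives 51.5% in this assay.

Compound 3 stands second highest of the three; its nearest neighbour is compound 1, separated by a number 4.8 percentage points lower from compound 1 to compound 3 (within the scatter), and its furthest is compound 2, separated by a number 38.4 percentage points higher from compound 2 to compound 3 (beyond the scatter). The unmeasured compound 4 is `O=C(C1CC1)N1CCN(Cc2nc3ccccc3n2CC2CCCC2)CC1`. It differs from compound 3 in one place: cyclopentyl in place of 4-methylphenyl on a saturated chain carbon bound to an aromatic nitrogen.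

For the measured compounds named here, two measured steps bear on this change, both swapping a six-membered aromatic ring for a group without one on the same saturated chain carbon. Going from an aromatic ring to isopropyl gave a number 43.2 percentage points lower from compound 1 to compound 2 (beyond the scatter), and the reverse swap gave a number 38.4 percentage points higher from compound 2 to compound 3 (beyond the scatter). Cyclopentyl, like isopropyl, is a saturated carbon group, so a clear fall in this assay is expected, though a ring of five carbons may not match isopropyl exactly. For compound 4 the estimated step is a number 29.5 percentage points lower from compound 3 to compound 4 (beyond the scatter), landing at 22% with a range from 8% to 42%.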

Compound 4, a percentage reported as inhibition, at one concentration (the size of the read-out at that concentration, not a potency): 44.5%
Compound 4: the middle estimate sits 22.5 percentage points below what was measured; measured number outside the range, above it.
By their numbers in this assay, from the lowest: compound 2; then compounds 4, 3 and 1 (each within the scatter of the next, the first and the last beyond it).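

In this assay, a saturated group at this position need not give a low number: cyclopentyl in place of isopropyl gives a number 31.4 percentage points higher from compound 2 to compound 4 (beyond the scatter), so the low number of compound 2 does not extend to every group without an aromatic ring. Cyclopentyl in place of 4-methylphenyl gives a number 7 percentage points lower from compound 3 to compound 4 (within the scatter), while cyclopentyl in place of 2-(trifluoromethyl)phenyl gives a number 11.8 percentage points lower from compound 1 to compound 4 (beyond the scatter), so a non-aromatic ring matches one of the aromatic groups but not the other. Nothing available here explains the difference between cyclopentyl and isopropyl.

Going by these compounds, it remains open whether the size of the saturated ring matters, as cyclopropyl or cyclohexyl at the same place could show. A saturated ring carrying an amine, or a longer open chain such as n-hexyl, is also untested among these compounds.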